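A few compounds are considered here, and "the series" means these few. Any claim that something is new, unique, unknown or untested is made for them only; others in the source may bear on it.

Measured so far:
compound 1 `CCCCCCCCc1cn(C2CCOC2=O)nn1` gives > 1000000 nM
compound 2 `CCCCCCCCCCCCc1cn(C2CCOC2=O)nn1` gives 670000 nM

Both numbers come from an ADME assay on MRC5 cells (Homo sapiens) for cytotoxicity, read by resazurin assay, with a stated time of 3 days; a lower number here means that less compound is tolerated, a higher number that more compound is tolerated. For compound 1 the result is a limit of the assay rather than a measured number (the limit of > 1000000 nM in this assay, at which 1 of the 2 values shown sits). Compound 2 carries a longer chain, and the step of an at least 1.4-fold lower number from compound 1 to compound 2 (0.17 log units; that floor lies within the scatter) stays inside the scatter, so these two compounds cannot be told apart on this read-out.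

Compound 3 `O=C1OCCC1n1cc(CCc2ccccc2)nn1` differs from compound 1 by phenyl in place of hexyl on a saturated chain carbon, two bonds along the chain from an aromatic carbon. Among the compounds with values here, the only measured step that bears on this change is an at least 1.4-fold lower number from compound 1 to compound 2 (0.17 log units; that floor lies within the scatter), which shows that lengthening the chain moved the value by no more than the scatter; shortening it and closing its end into a phenyl is therefore expected to give no step beyond the scatter either. Compound 3 is expected to sit around 1000000 nM, with a range from 400000 nM to 3000000 nM. The expected step is a number no higher from compound 1 to compound 3 (the limit leaves the size open).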

Compound 3, half-maximal cytotoxic concentration: > 1000000 nM
Compound 3: a limit, no number; the forecaster's own chance of this, stated with the estimate: 70%; the middle value sits exactly at the limit.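

Within the data shown here, compound 3, like compound 1, gives a limit of the assay rather than a number, so no step between the two can be read: the limit of > 1000000 nM in this assay, at which 2 of the 3 values shown sit. The compounds shown leave open whether phenyl in place of hexyl changes the true value in this assay at all.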